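The source may hold more compounds than are shown below. What is called first, only, known or untested is meant among the compounds shown, and "the series" means these compounds.

Compound 1 `O=C(O)c1ccc(C(=O)/C=C/c2ccc3c(c2)B(O)OC3)cc1` — > 10 ug/mL
Compound 2 `Cc1ccc(C(=O)/C=C/c2ccc3c(c2)B(O)OC3)cc1` — > 10 ug/mL
Compound 3 `Cc1cccc(C(=O)/C=C/c2ccc3c(c2)B(O)OC3)c1` — 8.56 ug/mL

Of the compounds shown here, three sharing one core have been tested in an ADME assay on L929 cells (Mus musculus) for cytotoxicity, read by resazurin assay, with a stated time of 72 h; a lower number here means a stronger inhibitor, a higher number a weaker inhibitor. Among the compounds with values here, compound 3 gives 8.56 ug/mL, the only actual number among the three results. Compound 1 gives > 10 ug/mL, which is a limit of the assay and not a number. Compound 2 likewise gives > 10 ug/mL, again a limit. Two of the three results therefore sit at the limit of > 10 ug/mL in this assay, at which 2 of the 3 values shown sit, and this shapes what can be read from the steps. The step that the two limits leave unreadable from compound 1 to compound 2 cannot be sized. The step of an at least 1.1-fold lower number from compound 2 to compound 3 (0.06 log units; that floor lies within the scatter) is the only readable one, and its floor lies within the usual scatter.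

The next compound, compound 4 `O=C(/C=C/c1ccc2c(c1)B(O)OC2)c1ccccc1`, differs from compound 3 in one place: hydrogen in place of methyl on an aromatic carbon. Within the data shown here, the one readable step, from compound 2 to compound 3, was small, and the other step is unreadable, so the account gives no ground for expecting a step beyond the scatter here. Compound 3 stands close to the limit at which the other two values sit, so a limit result for compound 4 is quite possible. The expected step is a 1.1-fold higher number from compound 3 to compound 4 (0.02 log units; within the scatter). Compound 4 is expected to give about 9 ug/mL, within 4.5 ug/mL to 18 ug/mL.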

Compound 4, half-maximal inhibitory concentration: > 10 ug/mL
Compound 4 gave a limit, no number (the forecaster's own chance of this, stated with the estimate: 50%); at least 1.1-fold (0.04 log units) between middle value and limit.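

In this assay compound 4 gives > 10 ug/mL, which is a limit of the assay and not a number. Replacing the methyl on an aromatic carbon with hydrogen, which turns 3-methylphenyl into phenyl, gives an at least 1.1-fold higher number from compound 3 to compound 4 (0.06 log units; that floor lies within the scatter), so the result sets only a floor for this change at this position, not its full size. Compound 3 remains the only compound with an actual number, the other steps involving compound 4 cannot be read, and the phenyl compound now joins the 4-methylphenyl and 4-carboxyphenyl compounds at the same limit: the limit of > 10 ug/mL in this assay, at which 3 of the 4 values shown sit.

Going by these compounds, the actual numbers behind the limits of compound 2 and compound 4 remain open, and with them the question of whether moving or removing the methyl changes the result by more than the usual scatter. On these data alone, it is also open what a methoxy group, a chlorine atom or an amine on the same aromatic carbon would give, and whether any of them would yield a number rather than a limit.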